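This account rests on a few compounds, and the source may have more. Where it says the series, first, only, none or still open, it means among the compounds named here.

Compound 1 `CC1(C(c2ccccc2)c2ccccc2)OS(=O)(=O)C=C1OCc1ccccc1` gives >= 400000 nM in an ADME assay on HEL cells (Homo sapiens) for cytotoxicity, with a stated time of 3 days (on this read-out lower numbers stand for higher toxicity in this test and higher numbers for lower toxicity in this test), which is a limit of the assay rather than a number. Compound 2 `CCC1(Cc2ccccc2)OS(=O)(=O)C=C1OCc1ccccc1Cl` gives >= 20000 nM in this assay, again a limit. Compound 3 `CC1(Cc2ccccc2)OS(=O)(=O)C=C1OCc1ccccc1` gives > 400000 nM in this assay, also a limit.

Compound 2 thus stands only at a limit, and the two other values shown are limits as well. Within the data shown here, the one step between measured compounds, a step that the two limits leave unreadable from compound 1 to compound 3, cannot be read because the limit of >= 400000 nM in this assay, at which 1 of the 3 values shown sits, and the limit of > 400000 nM in this assay, at which 1 of the 3 values shown sits, are both limits.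

Compound 4 `CCC1(Cc2ccccc2)OS(=O)(=O)C=C1OCc1ccc(C)cc1` differs from compound 2 by 4-methylphenyl in place of 2-chlorophenyl on a saturated chain carbon bound to an oxygen on an unsaturated carbon. No measured step touches this change, so nothing shown points in either direction, and since the limit of >= 20000 nM in this assay, at which 1 of the 3 values shown sits, is a limit, compound 2 itself offers no number to start from. The step from compound 2 to compound 4 is therefore expected to lie within the usual scatter, a step that the limit leaves unreadable from compound 2 to compound 4. Compound 4 is expected to give 40000 nM, in a range from 10000 nM to 400000 nM.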

Compound 4, minimum cytotoxic concentration: >= 16000 nM
Compound 4 ended at the assay's limit; the forecaster's own chance of this, stated with the estimate: 60%; the middle value does not contradict the limit.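

Compound 2 and compound 4 both stand only at limits of the assay, and no new step can be read from them, not even its direction. The compounds shown leave open at what concentration any of them would turn toxic in this assay, and whether changing a group shifts that concentration.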